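The source may report more compounds than this note shows. Statements on the series, on what has been measured and on what is new or still open speak of the compounds shown alone.

Measured compounds, all in a functional assay on MCF7 cells (Homo sapiens) for antiproliferative activity, read by MTT assay, with stated times of 24 h and 72 h; on this read-out lower numbers stand for stronger inhibition and higher numbers for weaker inhibition:

compound 1 `COc1ccc([C@@H]2[C@H](Oc3ccccc3)C(=O)N2c2cc(OC)c(OC)c(OC)c2)cc1OC`: 26000 nM
compound 2 `COc1cc(N2C(=O)[C@@H](Oc3ccccc3)[C@H]2c2cccc3ccccc23)cc(OC)c1OC`: 53000 nM
compound 3 `COc1cc(N2C(=O)[C@@H](Oc3ccccc3)[C@H]2c2ccc(S(C)(=O)=O)cc2)cc(OC)c1OC`: 62000 nM

Compound 1 stands at the lowest number of the three. Its nearest neighbour is compound 2, reached by a 2.0-fold higher number from compound 1 to compound 2 (0.31 log units; beyond the scatter); the furthest is compound 3, reached by a 2.4-fold higher number from compound 1 to compound 3 (0.38 log units; beyond the scatter). Between compound 2 and compound 3 the step is a 1.2-fold higher number from compound 2 to compound 3 (0.07 log units; within the scatter), so those two sit together.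

Compound 4 `COc1cc(N2C(=O)[C@@H](Oc3ccccc3)[C@H]2c2ccc(O)cc2)cc(OC)c1OC` differs from compound 1 in one place: 4-hydroxyphenyl in place of 3,4-dimethoxyphenyl on a saturated ring carbon. Both measured steps from compound 1 bear on it, since each also exchanges the group on that saturated ring carbon, and each gave a modest rise in the number. A third exchange at the same place is therefore expected to behave alike, with a modest rise rather than no change, though a single new group cannot be read from two others with confidence. For compound 4 the expected step is a 1.7-fold higher number from compound 1 to compound 4 (0.24 log units; within the scatter). Compound 4 is thus estimated at 45000 nM, with a range from 20000 nM to 100000 nM.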

Compound 4, half-maximal inhibitory concentration: 48000 nM
Beside the measured number, compound 4's estimate is 1.1-fold (0.03 log units) below it; the measured number falls inside the stated range.
By their numbers in this assay, from the lowest: compounds 1, 4, 2 and 3 (each within the scatter of the next, the first and the last beyond it).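

In this assay, among these compounds, 4-hydroxyphenyl is the first group in this set to bring a hydrogen-bond donor to the saturated ring carbon, and its step (a 1.8-fold higher number from compound 1 to compound 4 (0.27 log units; within the scatter)) lies within the scatter, unlike the two earlier exchanges from compound 1 at this place. The other two steps (a 1.1-fold lower number from compound 2 to compound 4 (0.04 log units; within the scatter)) and (a 1.3-fold lower number from compound 3 to compound 4 (0.11 log units; within the scatter)) also lie within the scatter, so the hydroxy-bearing compound cannot be separated from the naphthalen-1-yl or the 4-(methylsulfonyl)phenyl compound. No measurement at hand accounts for these steps.

Going by these compounds, it stays open whether a single 4-methoxyphenyl at this carbon would read like the 3,4-dimethoxyphenyl of compound 1 or like the hydroxy-bearing compound. Also open, on these data alone, is how an amine or a carboxylic acid at that ring position would read, and whether any group here could move the number beyond the scatter of compound 1 towards stronger inhibition.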